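A 3-methoxyphenyl swap at the assay limit

The compounds below may be only part of what the source reports. "The series", "measured", "known", "first", "only" and "open" are said of these compounds alone.

In an ADME assay on K562 cells (Homo sapiens) for cytotoxicity, with a stated time of 72 h (on this read-out lower numbers stand for stronger inhibition and higher numbers for weaker inhibition), compound 3 (`COc1ccccc1CNc1ncnc2c1ncn2C1CCCO1`) reads > 100000 nM, which is a limit of the assay and not a number. Compound 2 (`Oc1cccc(CNc2ncnc3c2ncn3C2CCCO2)c1`) reads > 100000 nM, and this too is a limit. Compound 3 therefore stands at the limit of > 100000 nM in this assay, at which 2 of the 3 values shown sit. Compound 1 (`COc1cccc(CNc2ncnc3c2ncn3C2CCCCO2)c1`) is the only one of the three with a true number, 61000 nM.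

Compound 4 (`COc1cccc(CNc2ncnc3c2ncn3C2CCCO2)c1`) differs from compound 3 in one place, on a saturated chain carbon bound to a nitrogen on an aromatic ring, where 3-methoxyphenyl takes the place of 2-methoxyphenyl: 3-methoxyphenyl in place of 2-methoxyphenyl on a saturated chain carbon bound to a nitrogen on an aromatic ring. Among the compounds with values here, the only measured step in this set is a step that the two limits leave unreadable from compound 2 to compound 3, so it offers no size to carry over. Within the data shown here, the sole guide is compound 1, which also carries the 3-methoxyphenyl group and gives 61000 nM. On that single value, a modest move towards stronger inhibition is expected in this assay, although a second reading at the limit would be no surprise. The estimated change is an at least 1.1-fold lower number from compound 3 to compound 4 (0.04 log units; that floor lies within the scatter), and it may prove no larger than the scatter. Compound 4 is expected at 90000 nM, with an estimated range of 45000 nM to 150000 nM.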

Compound 4, half-maximal inhibitory concentration: > 100000 nM
Compound 4: a limit, no number; the forecaster's own chance of this, stated with the estimate: 55%; middle value at least 1.1-fold (0.04 log units) away from the limit.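

In this assay compound 4 gives > 100000 nM, a limit of the assay and not a number, so 3-methoxyphenyl on a saturated chain carbon bound to a nitrogen on an aromatic ring leaves the oxolan-2-yl compounds where compound 3 already stood. The steps to compound 4 from compound 2 and from compound 3 join limit to limit and cannot be read, and the set now gathers at a single reading: the limit of > 100000 nM in this assay, at which 3 of the 4 values shown sit. Within the data shown here, the one readable step is oxolan-2-yl in place of oxan-2-yl on an aromatic nitrogen, an at least 1.6-fold higher number from compound 1 to compound 4 (0.21 log units; that floor lies within the scatter), so the new information concerns that group and not the methoxyphenyl position, though this floor does not by itself clear the scatter.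

Whether oxan-2-yl would also give a true number alongside 2-methoxyphenyl or 3-hydroxyphenyl stays open, since the only oxan-2-yl compound shown carries 3-methoxyphenyl. Also open, as far as these compounds go, is how an amine or a carboxylic acid in place of the methoxy group, or a longer chain on the aromatic nitrogen, would read in this assay.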